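This account rests on a few compounds, and the source may have more. Where it says the series, first, only, none or still open, it means among the compounds named here.

Compound 1 `COc1cccc(Oc2c(NS(=O)(=O)c3ccc(C(C)(C)C)cc3)ncnc2OCCOCc2ccccc2)c1` in an assay on cells (Endothelial cell) for binding affinity to Endothelin-1 receptor (Sus scrofa) (on this read-out higher numbers stand for weaker inhibition and lower numbers for stronger inhibition), gives 170 nM. Compound 2 `COc1cccc(Oc2c(NS(=O)(=O)c3ccc(C(C)(C)C)cc3)ncnc2OCCOc2ccncn2)c1` in this assay gives 1.2 nM. For the measured compounds named here, these two are joined by the only measured step, a 140-fold lower number from compound 1 to compound 2 (2.15 log units; beyond the scatter), which concerns the group at the end of the oxygen chain on the shared core. Compound 3 `CCC(C)(C)c1ccc(S(=O)(=O)Nc2ncnc(OCCOc3ncc(Br)cn3)c2-c2ccc(C)cc2)cc1` carries a different set of groups on that core. In this assay compound 3 gives < 0.001 nM, which is a limit of the assay and not a number. Among the three values shown, that of compound 3 stands at the limit of < 0.001 nM in this assay, at which 1 of the 3 values shown sits, so its exact place on the scale is not known.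

Compound 4 `Cc1ccc(-c2c(NS(=O)(=O)c3ccc(C(F)(F)F)cc3)ncnc2OCCOc2ncc(Br)cn2)cc1` differs from compound 3 in one place: trifluoromethyl in place of 1,1-dimethylpropyl on an aromatic carbon. Going by the values given here, no measured step touches this part of the structure; the single measured step concerns a different part of the molecule, so the measured data give no guide to the size or direction of the change. In the absence of such a guide, the expected step is an at least 10-fold higher number from compound 3 to compound 4 (1.00 log units; beyond the scatter), a moderate weakening that stays well within the potent range. Compound 4 is therefore estimated at 0.01 nM, with a range from 0.0005 nM to 0.5 nM, and a real chance that this assay again reports only a limit.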

Compound 4, half-maximal inhibitory concentration: 1.4 nM
Beside the measured number, compound 4's estimate is 140-fold (2.15 log units) below it; measured number outside the range, above it.
By their numbers in this assay, from the lowest: compounds 2 and 4 (each within the scatter of the next); then compound 1. At a limit, below all of these: compound 3.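

For the compounds shown here, until now the only measured step concerned the end of the oxygen chain, so nothing showed whether the group at this other place on the molecule mattered. In this assay it matters greatly: changing 4-(1,1-dimethylpropyl)phenyl to 4-(trifluoromethyl)phenyl gives an at least 1400-fold higher number from compound 3 to compound 4 (3.14 log units; beyond the scatter), even though the two groups are close in heavy-atom count and neither has a hydrogen-bond donor or acceptor, so these counts alone do not separate them. From the compounds shown here alone, the true size of the step remains unknown because the value of compound 3 is a limit of the assay and not a number: the limit of < 0.001 nM in this assay, at which 1 of the 4 values shown sits.

Going by these compounds, with only these two groups compared at this place, it remains open whether a smaller carbon group such as isopropyl, or a single chlorine atom, would keep more of the strength of compound 3. On these data alone, it is also open whether the same change would have an effect of similar size in a compound carrying the different groups of compound 2, and the data give no reason for the loss.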